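The compounds below may be only part of what the source reports. "The series", "measured", "known", "first", "only" and "open" are said of these compounds alone.

Series notes. Within the data shown here, compound 1 `C[C@@H]1CCN(c2cc(-c3ccccc3)nc3ncnn23)C[C@@H]1N(C)c1ncnc2[nH]ccc12` gives 84900 nM in a functional assay on MGC-803 cells (Homo sapiens) for inhibition, read by MTT assay, with a stated time of 72 h (a lower number here means a stronger inhibitor, a higher number a weaker inhibitor), and compound 2 `CCc1cc(N2CC[C@@H](C)[C@@H](N(C)c3ncnc4[nH]ccc34)C2)n2ncnc2n1` gives 80200 nM; the step of a 1.1-fold lower number from compound 1 to compound 2 (0.02 log units; within the scatter) is the only paired comparison so far. Compound 3 `Cc1cc(N2CC[C@@H](C)[C@@H](N(C)c3ncnc4[nH]ccc34)C2)n2nc(SCc3ccccc3Br)nc2n1` gives 27000 nM and stands lowest of the three, beyond the scatter from both compound 2 and compound 1. Compound 4 `C#CSc1nc2nc(C)cc(N3CC[C@@H](C)[C@@H](N(C)c4ncnc5[nH]ccc45)C3)n2n1` differs from compound 3 in one place: ethynyl in place of 2-bromobenzyl on a sulfur. Among the measured compounds shown here, no measured step touches this sulfur substituent, so the one measured step gives no direct guide; compound 3 stands apart from compound 2 in two places at once, so its lower number cannot be assigned to the sulfanyl group alone. Compound 4 is therefore expected near 50000 nM, range 15000 nM to 150000 nM, a step of a 1.9-fold higher number from compound 3 to compound 4 (0.27 log units; within the scatter) expected to be small and uncertain in direction.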

Compound 4, half-maximal inhibitory concentration: 18100 nM
Compound 4: the middle estimate sits 2.8-fold (0.44 log units) above what was measured, within the range that was stated.
By their numbers in this assay, from the lowest: compounds 4 and 3 (each within the scatter of the next); then compounds 2 and 1 (each within the scatter of the next).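

In this assay the change on the sulfur from 2-bromobenzyl to ethynyl gives a 1.5-fold lower number from compound 3 to compound 4 (0.17 log units; within the scatter). The sulfur substituent can therefore go from 8 heavy atoms to 2, losing both the six-membered aromatic ring and the bromine, with no step beyond the scatter. No measured evidence bears on why this change leaves the number within the scatter. Still open, on these data alone, is whether an amine, a carboxylic acid or a longer chain on this sulfur would give a step beyond the scatter.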